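The source may report more compounds than this note shows. Statements on the series, on what has been measured and on what is new or still open speak of the compounds shown alone.

Three compounds sharing one core were measured in an assay on isolated protein for inhibition of E3 ubiquitin-protein ligase Mdm2 (Homo sapiens), read by fluorescence polarization, with a stated time of 30 min; on this read-out higher numbers stand for weaker inhibition and lower numbers for stronger inhibition. Compound 1 `CCOc1cc(C(C)(C)C)ccc1C1=NC(c2ccc(Cl)cc2)C(c2ccc(Cl)cc2)N1C(=O)NCCCCCCCC(=O)Nc1ccccc1N` gives 1020 nM, compound 3 `CCOc1cc(C(C)(C)C)ccc1C1=NC(c2ccc(Cl)cc2)C(c2ccc(Cl)cc2)N1C(=O)NCCCCCCCC(=O)NO` gives 340 nM, and compound 2 `CCOc1cc(C(C)(C)C)ccc1C1=NC(c2ccc(Cl)cc2)C(c2ccc(Cl)cc2)N1C(=O)N1CCN(CCCCCC(=O)NO)CC1` gives 170 nM. Going by the values given here, the only step between compounds that differ in one place, a 3.0-fold lower number from compound 1 to compound 3 (0.48 log units; beyond the scatter), concerns a group on an amide-type nitrogen. Compound 2 holds the lowest of the three numbers; its gap to compound 3 lies within the scatter, while its gap to compound 1 lies beyond it. Compound 4 `CCOc1cc(C(C)(C)C)ccc1C1=NC(c2ccc(Cl)cc2)C(c2ccc(Cl)cc2)N1C(=O)N1CCN(CCCCC(=O)NO)CC1` differs from compound 2 by hydroxycarbamoyl in place of (hydroxycarbamoyl)methyl on a saturated chain carbon, four bonds along the chain from an amine nitrogen in a ring, a change on the saturated chain, four bonds along the chain from an amine nitrogen in a ring. Among the compounds with values here, no measured step touches this chain; the step of a 1.2-fold higher number from compound 2 to compound 4 (0.07 log units; within the scatter) is therefore expected to lie within the scatter. For compound 4 the estimate is 200 nM, with a range from 80 nM to 500 nM.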

Compound 4, inhibition constant: 170 nM
Beside the measured number, compound 4's estimate is 1.2-fold (0.07 log units) above it, within the range that was stated.
By their numbers in this assay, from the lowest: compounds 2, 4 and 3 (each within the scatter of the next); then compound 1.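

Going by these compounds alone, on the saturated chain, four bonds along the chain from an amine nitrogen in a ring, hydroxycarbamoyl in place of (hydroxycarbamoyl)methyl gives no change at the digits printed from compound 2 to compound 4 (within the scatter) in this assay, the first measured step on this chain. The number at this position therefore holds when the chain loses one carbon. Nothing available explains this result. As far as these compounds go, whether a much shorter chain, a longer chain, or a carboxylic acid in place of the hydroxycarbamoyl end would also hold the number stays open. So does whether the same shortening would behave alike on the chain of compound 3.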